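A few compounds are considered here, and "the series" means these few. Any claim that something is new, unique, unknown or untested is made for them only; others in the source may bear on it.

Measured compounds in an assay on isolated protein for inhibition of Gonadotropin-releasing hormone receptor (Rattus norvegicus); on this read-out lower numbers stand for stronger inhibition and higher numbers for weaker inhibition:

Compound 1 `COc1ccccc1CSc1nc2cc(NC(=O)C3CC3)ccc2n1C(C)C` — in this assay compound 1 reaches only the assay limit > 10000 nM.
Compound 2 `COc1ccc(C#N)cc1CSc1nc2cc(NC(=O)C3CC3)ccc2n1C(C)C` — in this assay compound 2 likewise stops at the limit > 10000 nM.
Compound 3 `CCCCCn1c(SCc2cc([N+](=O)[O-])ccc2OC)nc2cc(NC(=O)NC(C)(C)C)ccc21` — in this assay compound 3 gives 880 nM.

Among the compounds with values here, compound 3 therefore stands as the only measured number in the set; the other two values are limits, as the limit of > 10000 nM in this assay, at which 2 of the 3 values shown sit, records. Within the data shown here, the single step between measured compounds, a step that the two limits leave unreadable from compound 1 to compound 2, runs between two limits and its size cannot be read.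

Compound 4 `COc1ccc([N+](=O)[O-])cc1CSc1nc2cc(NC(=O)NC(C)(C)C)ccc2n1C(C)C` differs from compound 3 by isopropyl in place of pentyl on an aromatic nitrogen. Among the measured compounds shown here, no measured step alters the group on the aromatic nitrogen, so nothing in the set bears directly on this change. Compounds 1 and 2 carry isopropyl there, but they differ from compound 3 in more than one place; their values show only the limit where compound 3 shows a number. On that thin basis a step toward weaker inhibition is expected, though with wide uncertainty. Compound 4 is expected to show a 3.4-fold higher number from compound 3 to compound 4 (0.53 log units; beyond the scatter). Compound 4 is estimated at 3000 nM, within a range from 700 nM to 12000 nM.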

Compound 4, half-maximal inhibitory concentration: 62 nM
Beside the measured number, compound 4's estimate is 48-fold (1.68 log units) above it, outside the stated range (below it).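

Within the data shown here, the change of pentyl to isopropyl on the aromatic nitrogen gives the first readable step at this position in this assay: a 14-fold lower number from compound 3 to compound 4 (1.15 log units; beyond the scatter). With the rest of the structure the same in both compounds, the group on this nitrogen alone makes a large difference to the read-out, and the smaller, branched isopropyl goes with the stronger inhibition of the pair. Nothing in the data at hand gives a reason for this step.

The pair does not separate the length of the chain from its branching, since pentyl and isopropyl differ in both. Going by these compounds, how a straight propyl chain, a tert-butyl group or a cyclopentyl ring on the same nitrogen would read remains open, as does whether the step holds with other groups elsewhere on the core.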